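A few compounds are considered here, and "the series" means these few. Any claim that something is new, unique, unknown or untested is made for them only; others in the source may bear on it.

Measured compounds in a functional assay on CAKI-1 cells (Homo sapiens) for inhibition, read by sulforhodamine B assay, with a stated time of 48 h, tested at 10 uM; on this read-out higher numbers stand for a weaker effect at the one concentration tested and lower numbers for a stronger effect:

Compound 1, `COc1cc(Cl)cc(-c2nn(-c3cccc(NC(=O)c4ccc(Cl)c(Cl)c4)c3)cc2-c2ccncc2)c1`, gives 63.6%.
Compound 2, `COc1cc(Cl)cc(-c2nn(-c3cccc(NC(=O)Nc4ccc(Cl)c(Cl)c4)c3)cc2-c2ccncc2)c1`, gives 7.49%.
Compound 3, `COc1cc(Cl)cc(-c2nn(-c3cccc(NC(=O)c4cccc(C(F)(F)F)c4)c3)cc2-c2ccncc2)c1`, gives 54%.

Compound 3 stands second highest of the three numbers; its nearest neighbour is compound 1, and the two lie within the scatter of each other, so nothing separates them, while compound 2 lies far below, as the step of a number 46.5 percentage points higher from compound 2 to compound 3 (beyond the scatter) shows.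

Compound 4, `COc1cc(Cl)cc(-c2nn(-c3cccc(NC(=O)c4cc(C(F)(F)F)cc(C(F)(F)F)c4)c3)cc2-c2ccncc2)c1`, differs from compound 3 in one place: trifluoromethyl in place of hydrogen on an aromatic carbon. For the measured compounds named here, no measured step exchanges a hydrogen for a trifluoromethyl group on that ring, so the closest guidance is indirect. The step of a number 9.6 percentage points lower from compound 1 to compound 3 (within the scatter) exchanged one aryl group on the carbonyl carbon for another and moved the number only within the scatter, whereas the large steps of a number 56.1 percentage points lower from compound 1 to compound 2 (beyond the scatter) and a number 46.5 percentage points higher from compound 2 to compound 3 (beyond the scatter) came from changing the link to the carbonyl, which compound 4 keeps unchanged. The expected step of a number 4 percentage points lower from compound 3 to compound 4 (within the scatter) is therefore small, likely within the scatter. Compound 4 is estimated at 50%, in a range from 30% to 75%.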

Compound 4, a percentage reported as activity, at one concentration (the size of the read-out at that concentration, not a potency): 68.6%
The estimate for compound 4 lay 18.6 percentage points below the measured number; the measured number falls inside the stated range.
By their numbers in this assay, from the lowest: compound 2; then compounds 3, 1 and 4 (each within the scatter of the next, the first and the last beyond it).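

In this assay, adding a second trifluoromethyl group to the aromatic ring on the carbonyl carbon, meta to the first, gives a number 14.6 percentage points higher from compound 3 to compound 4 (beyond the scatter), so the effect at the one tested concentration is weaker. The earlier exchange of one aryl group for another, a number 9.6 percentage points lower from compound 1 to compound 3 (within the scatter), could not separate its two compounds, whereas this single addition to the ring does, though it remains modest beside the large change in the link to the carbonyl, a number 56.1 percentage points lower from compound 1 to compound 2 (beyond the scatter). No measurement here explains why the added group weakens the effect.

The compounds shown leave open whether a smaller group at this position, such as a fluorine, a nitrile or an amine, would also weaken the effect. They also leave open whether adding trifluoromethyl would cost as much with the link found in compound 2.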